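The source may report more compounds than this note shows. Statements on the series, on what has been measured and on what is new or still open speak of the compounds shown alone.

In a functional assay on A498 cells (Homo sapiens) for inhibition, read by sulforhodamine B assay, with a stated time of 48 h (on this read-out higher numbers stand for weaker inhibition of growth and lower numbers for stronger inhibition of growth), compound 2 `COc1cc(-c2nn(-c3cccc(NC(=O)Nc4ccc(Cl)c(Cl)c4)c3)cc2-c2ccncc2)ccc1Cl` gives 1140 nM. Compound 1 `O=C(Nc1cccc(-n2cc(-c3ccncc3)c(-c3ccc(Cl)c(O)c3)n2)c1)Nc1cccc(C(F)(F)F)c1` gives 2240 nM in this assay, and the two numbers lie within the scatter of each other, so compound 2 cannot be set apart from compound 1 on these data. Compound 3 `O=C(Nc1cccc(-n2cc(-c3ccncc3)c(-c3ccc(Cl)c(O)c3)n2)c1)Nc1ccc(Cl)c(Cl)c1` has not yet been measured; it differs from compound 2 by hydrogen in place of methyl on an oxygen on an aromatic ring, a methoxy becoming a hydroxy. For the measured compounds named here, no measured pair shows this single change on its own, so the expected step of a 1.3-fold higher number from compound 2 to compound 3 (0.12 log units; within the scatter) is one that stays within the scatter. Compound 3 is estimated at 1500 nM, with a range from 600 nM to 4000 nM.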

Compound 3, concentration for 50% growth inhibition: 940 nM
Estimate against measurement, compound 3: 1.6-fold (0.20 log units) above; the measured number falls inside the stated range.
By their numbers in this assay, from the lowest: compounds 3, 2 and 1 (each within the scatter of the next, the first and the last beyond it).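

In this assay, replacing methoxy with hydroxy on the aromatic ring gives a 1.2-fold lower number from compound 2 to compound 3 (0.08 log units; within the scatter), so compound 2 and compound 3 cannot be told apart at this position. With the hydroxy kept, 3,4-dichlorophenyl in place of 3-(trifluoromethyl)phenyl on the amide-type nitrogen gives a 2.4-fold lower number from compound 1 to compound 3 (0.38 log units; beyond the scatter), a modest but real step and the first one here beyond the scatter. Nothing measured here explains the size of either step.

From the compounds shown here alone, it remains open how an amine or a longer chain such as ethoxy in place of the hydroxy would behave. Going by these compounds, it is also open whether a carboxylic acid on the phenyl ring attached to the amide-type nitrogen would keep this level of growth inhibition.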